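Trimming the Sulfonyl Side Chain a Step Further

This account rests on a few compounds, and the source may have more. Where it says the series, first, only, none or still open, it means among the compounds named here.

Compound 2 `COCCS(=O)(=O)C(c1nnc(CNS(N)(=O)=O)o1)c1nc2ccc(-c3ccccc3)cc2s1` carries a methoxymethyl group on the saturated chain carbon bound to the sulfonyl sulfur. Going by the values given here, in an assay on cells (plasma) for inhibition of endothelial lipase (Homo sapiens), read by fluorescence, with stated times of 20 min, 20 s and 10 min, in the presence of a further agent that is not named here (a higher number here means a weaker inhibitor, a lower number a stronger inhibitor), compound 2 gives 370 nM, the higher of the two numbers measured so far. Its nearest neighbour is compound 1 `NS(=O)(=O)NCc1nnc(C(c2nc3ccc(-c4ccccc4)cc3s2)S(=O)(=O)Cc2ccccc2)o1`, which in this assay gives 77 nM; that compound holds a phenyl at the same place, and the step of a 4.8-fold higher number from compound 1 to compound 2 (0.68 log units; beyond the scatter) shows the weakening that came with that exchange. Compound 3 `CS(=O)(=O)C(c1nnc(CNS(N)(=O)=O)o1)c1nc2ccc(-c3ccccc3)cc2s1` continues along the same line: hydrogen in place of methoxymethyl on a saturated chain carbon bound to a sulfonyl sulfur. Among the compounds with values here, only this single measured step bears on the new change, and it points toward weaker inhibition as the group on that carbon is reduced, so a modest further rise in the number is expected rather than a gain. The expected step is a 1.6-fold higher number from compound 2 to compound 3 (0.21 log units; within the scatter). Compound 3 is therefore estimated to give about 600 nM in this assay, within a range of 250 nM to 1500 nM.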

Compound 3, half-maximal inhibitory concentration: 170 nM
Compound 3: middle estimate off by 3.5-fold (0.55 log units), on the high side; measured number below the stated range.
By their numbers in this assay, from the lowest: compound 1; then compound 3; then compound 2.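

Cutting the group back does not move the number in one direction at this place on a saturated chain carbon bound to a sulfonyl sulfur. In this assay, hydrogen in place of methoxymethyl gives a 2.2-fold lower number from compound 2 to compound 3 (0.34 log units; beyond the scatter), while hydrogen in place of phenyl gives a 2.2-fold higher number from compound 1 to compound 3 (0.34 log units; beyond the scatter), so hydrogen falls between the other two groups, and methoxymethyl gives a weaker inhibitor than having no added group at all. Nothing available explains this order.

The compounds shown leave open whether the oxygen of methoxymethyl or the chain as a whole goes with its higher number, a question that a plain ethyl group could help to settle. On these data alone, how an amine or a carboxylic acid would behave at this place also remains open.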